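Replacing the Hydroxy of Compound 2

The source may hold more compounds than are shown below. What is called first, only, known or untested is meant among the compounds shown, and "the series" means these compounds.

Going by the values given here, only two compounds sharing one core have been tested so far in a functional assay on Bel-7402 cells (Homo sapiens) for inhibition, read by MTT assay, with a stated time of 24 h, tested at 1 ug/mL; a lower number here means less inhibition of growth, a higher number more inhibition of growth at the concentration tested. In that test, compound 1 `CC(=O)SCCC(CCCCC(=O)O)SC(C)=O` gives 12.8%. Compound 2 `O=C(O)CCCCC(CCSC(=O)c1ccccc1)SC(=O)c1ccccc1` is recorded as "not active" (no number reported), so it offers a verdict rather than a number as the starting point.

The next structure is compound 3 `O=C(CCCCC(CCSC(=O)c1ccccc1)SC(=O)c1ccccc1)Nc1ccc(Cl)cc1`. The change, ((4-chlorophenyl)amino in place of hydroxy on a carbonyl carbon), puts (4-chlorophenyl)amino in place of hydroxy on a carbonyl carbon, which turns carboxy into (4-chlorophenyl)carbamoyl. Among the compounds with values here, this adds a whole aromatic ring to the end of the chain, yet no measured pair shows what such a swap does, so any forecast here is loose.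

Within the data shown here, the only number available is the low one of compound 1 at 12.8%, and it gives little reason to expect much growth inhibition from this family in this assay. A small rise over compound 2 is expected, possibly none that could be told from the usual scatter. For compound 3, the estimated growth inhibition is 12%, with an expected range from 0% to 35%.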

Compound 3, percent growth inhibition at one concentration: 9.62%
Estimate against measurement, compound 3: 2.4 percentage points above; low and high end bracket the measured number.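

No step can be read from compound 2 to compound 3: in this assay compound 2 has only the verdict "not active" and no number, whereas compound 3 gives 9.62% as a number. No available evidence bears on this result. The compounds shown leave open how far (4-chlorophenyl)amino in place of hydroxy shifts growth inhibition, if at all.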